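Sulfonyl in place of benzyl on the ring nitrogen

A few compounds are considered here, and "the series" means these few. Any claim that something is new, unique, unknown or untested is made for them only; others in the source may bear on it.

Measured so far:
compound 1 `COc1ccc(-c2cc(=O)c3c(OC)cc(OC)cc3n2Cc2ccccc2)cc1`: > 34400 nM
compound 2 `COC(=O)c1cc(=O)c2c(OC)cc(OC)cc2n1C`: > 37900 nM
compound 3 `COc1ccc(-c2cc(=O)c3c(OC)cc(OC)cc3n2S(=O)(=O)c2ccc([N+](=O)[O-])cc2)cc1`: 17100 nM

Compound 1 `COc1ccc(-c2cc(=O)c3c(OC)cc(OC)cc3n2Cc2ccccc2)cc1` was tested in a functional assay on SUP-B15 cells (Homo sapiens) for antiproliferative activity, with a stated time of 72 h (on this read-out lower numbers stand for an effect already at smaller amounts and higher numbers for an effect only at larger amounts of compound), and gives only a limit, > 34400 nM; it is a limit of the assay, not a number (the limit of > 34400 nM in this assay, at which 1 of the 3 values shown sits). Compound 2 `COC(=O)c1cc(=O)c2c(OC)cc(OC)cc2n1C` likewise returns only a limit in this assay, > 37900 nM (the limit of > 37900 nM in this assay, at which 1 of the 3 values shown sits). Going by the values given here, compound 3 `COc1ccc(-c2cc(=O)c3c(OC)cc(OC)cc3n2S(=O)(=O)c2ccc([N+](=O)[O-])cc2)cc1` is the one compound of the three with a number in this assay, 17100 nM. On the values shown compound 1 therefore stands at a limit, with no number to rank it against compound 3.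

The step under consideration leads from compound 1 to compound 4 `COc1ccc(-c2cc(=O)c3c(OC)cc(OC)cc3n2S(=O)(=O)c2ccc(Br)cc2)cc1`. The change is (4-bromophenyl)sulfonyl in place of benzyl on an aromatic nitrogen, on the aromatic nitrogen of the shared core: a benzyl leaves and a (4-bromophenyl)sulfonyl enters. Among the compounds with values here, no step between measured compounds is available, so the size of the step rests on the values alone. Compound 3 also carries a sulfonyl on that nitrogen and gives 17100 nM, a number. The expectation for compound 4 is therefore a value near that of compound 3, with a fair chance that only a limit is returned. Compound 4 is expected at 18000 nM, within 6000 nM to 50000 nM. The expected step from compound 1 to compound 4 is an at least 1.9-fold lower number from compound 1 to compound 4 (0.28 log units; that floor lies within the scatter), which cannot be sized against a limit.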

Compound 4, half-maximal effective concentration: 63800 nM
Compound 4: middle estimate off by 3.5-fold (0.55 log units), on the low side, outside the stated range (above it).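

Working notes on the sulfonyl compounds. With the sulfonyl kept on the aromatic nitrogen of the shared core, bromo in place of nitro on an aromatic carbon gives, in this assay, a 3.7-fold higher number from compound 3 to compound 4 (0.57 log units; beyond the scatter). The earlier compounds shown here held a single sulfonyl example, whereas this pair shows that a sulfonyl on that nitrogen does not by itself fix the read-out, since the group carried on its aromatic ring also moves it. The steps from compound 1 cannot be read, because compound 1 gives only a limit of the assay: the limit of > 34400 nM in this assay, at which 1 of the 4 values shown sits.

Still open, going by these compounds, is whether an amine or a carboxylic acid in place of bromo or nitro on that aromatic ring would give a number lower than that of compound 3, and whether a longer chain in place of the aromatic ring on the sulfonyl would keep any effect in this assay. With only compound 3 and compound 4 giving numbers, no trend across groups on the sulfonyl can be drawn, and how the sulfonyl compounds compare with a benzyl on that nitrogen remains unsettled.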